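The compounds below may be only part of what the source reports. "The series", "measured", "known", "first", "only" and "open" are said of these compounds alone.

Compound 1 `CC(=O)c1ccc(S(=O)(=O)N[C@@H](C)Cn2ccc(-c3ccc(C#N)c(Cl)c3)n2)cc1` gives 5230 nM in a functional assay on LNCaP cells (Homo sapiens) for antiproliferative activity, read by CCK-8 assay, with a stated time of 6 days; a higher number here means a weaker inhibitor, a lower number a stronger inhibitor.
Compound 2 `C[C@@H](Cn1ccc(-c2ccc(C#N)c(Cl)c2)n1)NS(=O)(=O)c1cn(C)cn1` gives > 30000 nM in this assay.
Compound 3 `C[C@@H](Cn1ccc(-c2ccc(C#N)c(Cl)c2)n1)Nc1cccc2ncccc12` gives 1080 nM in this assay.

Compound 2 stands at the limit of this assay: its reading is a boundary of the assay rather than a measured number, and it matches (the limit of > 30000 nM in this assay, at which 1 of the 3 values shown sits). Compound 4 `C[C@@H](Cn1ccc(-c2ccc(C#N)c(Cl)c2)n1)Nc1ncnc2nc[nH]c12` has not yet been measured. It differs from compound 2 in one place: a group of 9 heavy atoms (5 carbon, 4 nitrogen; one five-membered aromatic ring with 2 hetero atoms, one six-membered aromatic ring with 2 hetero atoms) in place of a group of 9 heavy atoms (4 carbon, 2 nitrogen, 2 oxygen, 1 sulfur; one five-membered aromatic ring with 2 hetero atoms), on an amine nitrogen. Going by the values given here, the only measured step, an at least 5.7-fold higher number from compound 1 to compound 2 (0.75 log units; beyond the scatter), concerns the group on the sulfonyl sulfur, so it bears only loosely on this change; it does show that a swap in this region can shift the number by a modest amount. Compound 3 also carries an aromatic group directly on that amine nitrogen instead of a sulfonyl, and compound 3 gave 1080 nM in this assay. A number in that neighbourhood is therefore expected for compound 4, estimated at 3000 nM with a range from 600 nM to 20000 nM. That estimate would mean an expected step of an at least 10-fold lower number from compound 2 to compound 4 (1.00 log units; beyond the scatter).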

Compound 4, half-maximal inhibitory concentration: 960 nM
Compound 4: the middle estimate sits 3.1-fold (0.49 log units) above what was measured; measured number inside the range.
By their numbers in this assay, from the lowest: compounds 4 and 3 (each within the scatter of the next); then compound 1. At a limit, above all of these: compound 2.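

Putting this two-ring aromatic group on the amine nitrogen in place of the (1-methyl-1H-imidazol-4-yl)sulfonyl group gives an at least 31-fold lower number from compound 2 to compound 4 (1.49 log units; beyond the scatter), the largest step shown so far. From the compounds shown here alone, compound 2 gives only a limit of the assay and not a number, and the true size of that step stays unknown: the limit of > 30000 nM in this assay, at which 1 of the 4 values shown sits. Compound 3 and compound 4 both carry an aromatic group directly on that nitrogen, and their readings in this assay lie within the usual scatter of each other, so these two different aromatic groups cannot be told apart here.

Going by these compounds, whether the lower number comes from the new rings or from the loss of the sulfonyl stays open. A small group such as methyl or acetyl on that amine nitrogen would help to separate the two, and a saturated ring such as piperidine would test whether an aromatic group is needed there at all.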